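This account rests on a few compounds, and the source may have more. Where it says the series, first, only, none or still open, it means among the compounds named here.

Measured so far in a functional assay on HCC827 cells (Homo sapiens) for inhibition, read by fluorescence, with a stated time of 72 h; a lower number here means a stronger inhibitor of growth, a higher number a weaker inhibitor of growth:
- compound 1, `CC(C)CCn1cnc2c(Nc3ccccc3)nc(N[C@H]3CC[C@H](N)CC3)nc21`: 21700 nM
- compound 2, `CCCCn1cnc2c(Nc3ccc(Cl)cc3)nc(N[C@H]3CC[C@H](N)CC3)nc21`: 10800 nM
- compound 3, `CCCCn1cnc2c(Nc3ccccc3)nc(N[C@H]3CC[C@H](N)CC3)nc21`: 9000 nM

Going by the values given here, compound 3 gives the lowest of the three numbers, though its gap to compound 2 lies within the scatter; only compound 1 stands apart, the step of a 2.4-fold lower number from compound 1 to compound 3 (0.38 log units; beyond the scatter) being the one clear change in the set. The other step, a 1.2-fold lower number from compound 2 to compound 3 (0.08 log units; within the scatter), stays within the scatter.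

Compound 4, `CCCCn1cnc2c(Nc3cc(OC)cc(OC)c3)nc(N[C@H]3CC[C@H](N)CC3)nc21`, differs from compound 3 in one place: 3,5-dimethoxyphenyl in place of phenyl on a nitrogen on an aromatic ring. Among the compounds with values here, of the measured steps only the one from compound 2 to compound 3 touches the same ring, and it was within the scatter; no change to the aryl group has yet moved this assay. Compound 4 is therefore expected to show no step beyond the scatter, no change at the digits printed from compound 3 to compound 4 (within the scatter), and its estimated value is 9000 nM, in the range 3000 nM to 27000 nM.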

Compound 4, concentration for 50% growth inhibition: 20100 nM
Estimate against measurement, compound 4: 2.2-fold (0.35 log units) below; the range from low to high includes it.
By their numbers in this assay, from the lowest: compounds 3, 2, 4 and 1 (each within the scatter of the next, the first and the last beyond it).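

Of the steps at the aryl group on the nitrogen, the change to 3,5-dimethoxyphenyl from phenyl is the only one beyond the scatter in this assay, with a 2.2-fold higher number from compound 3 to compound 4 (0.35 log units; beyond the scatter). Measured against 4-chlorophenyl, the same group stays within the scatter, with a 1.9-fold higher number from compound 2 to compound 4 (0.27 log units; within the scatter), so no aryl group shown here improves on phenyl beyond the scatter. No measured data bearing on this step are available.

Open, from the compounds shown here alone, is whether a single methoxy group would produce the same step, and whether an amine or a carboxylic acid on the phenyl ring would give a lower number than compound 3.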